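The compounds below may be only part of what the source reports. "The series", "measured", "known", "first", "only" and "open" are said of these compounds alone.

Compound 1 `CN(C)C(=O)c1ccncc1Nc1cc(-c2ccc3ccn(C)c3c2)c2nccnc2c1`: 0.35 h
Compound 2 `Cn1ccc2ccc(-c3cc(Nc4cnccc4C(=O)NC4CCNC(=O)C4)cc4nccnc34)cc21`: > 1 h

Both were measured in an ADME assay on microsomes from liver (Mus musculus, strain CD-1) for metabolic stability, read by LC-MS, tested at 2 uM; a lower number here means that the compound disappears faster, a higher number that the compound lasts longer. For compound 2, > 1 h is a limit of the assay and not a number. Compound 3 `CN1CC(NC(=O)c2ccncc2Nc2cc(-c3ccc4ccn(C)c4c3)c3nccnc3c2)C1` carries 1-methylazetidin-3-yl in place of 2-oxopiperidin-4-yl on an amide-type nitrogen. Going by the values given here, only one measured step bears on this: an at least 2.8-fold higher number from compound 1 to compound 2 (0.45 log units; beyond the scatter). That step brought in the group that now leaves, so part of its gain is expected to go. The expected change is an at least 1.6-fold lower number from compound 2 to compound 3 (0.22 log units; that floor lies within the scatter), towards a lower number. For compound 3 the estimated half-life is 0.6 h, with an expected range of 0.25 h to 1.3 h.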

Compound 3, half-life: > 1 h
Compound 3: only a limit was reported; the forecaster's own chance of this, stated with the estimate: 20%; at least 1.6-fold (0.22 log units) between middle value and limit.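

In this assay, swapping dimethylamino for (1-methylazetidin-3-yl)amino on the carbonyl carbon gives an at least 2.8-fold higher number from compound 1 to compound 3 (0.45 log units; beyond the scatter). The gain first seen with 2-oxopiperidin-4-yl is therefore not tied to that group, since a smaller ring with no carbonyl and no hydrogen-bond donor also gives it. The step from compound 2 to compound 3 cannot be read, and compound 2 and compound 3 cannot be ranked: the limit of > 1 h in this assay, at which 2 of the 3 values shown sit.

Going by these compounds, how far either compound lies past that limit stays open. So does whether an open-chain amine or a carboxylic acid on the amide-type nitrogen would keep the gain.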